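Thiourea sulfonamides: swapping the sulfonamide substituent

The source may hold more compounds than are shown below. What is called first, only, known or untested is meant among the compounds shown, and "the series" means these compounds.

Working notes on a small set of quinoline sulfonamides tested for antiproliferative activity. The series is characterised in a functional assay on MDA-MB-231 cells (Homo sapiens) for antiproliferative activity, read by sulforhodamine B assay, with a stated time of 48 h; a higher number here means a weaker inhibitor, a lower number a stronger inhibitor. The urea analogue compound 1 `O=C(Nc1ccccc1)Nc1ccc(S(=O)(=O)Nc2ccnc3cc(C(F)(F)F)ccc23)cc1` gives 52900 nM in this assay. The thiourea compound 3 `Cc1cc(NS(=O)(=O)c2ccc(N/C(S)=N\c3ccnc4cc(C(F)(F)F)ccc34)cc2)on1`, carrying a methylisoxazolyl group on the sulfonamide nitrogen, gives 80300 nM in this assay; the two values of compound 1 and compound 3 lie close to each other and no ordering is drawn from them. Compound 2 `N=C(N)NS(=O)(=O)c1ccc(N/C(S)=N\c2ccnc3cc(C(F)(F)F)ccc23)cc1`, in which the sulfonamide nitrogen carries a guanidine-type group, is recorded in this assay only as "not active" (no number reported), so no single number places it relative to compound 1 or compound 3.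

The step of interest leads to compound 4 `O=S(=O)(Nc1nccs1)c1ccc(N/C(S)=N\c2ccnc3cc(C(F)(F)F)ccc23)cc1`. The change from compound 2 is a group of 5 heavy atoms (3 carbon, 1 nitrogen, 1 sulfur; one five-membered aromatic ring with 2 hetero atoms) in place of a group of 3 heavy atoms (1 carbon, 2 nitrogen; no ring), on a sulfonamide nitrogen. Among the compounds with values here, no measured pair covers this exact change, so the size of the step in this assay cannot be read from the data; the only guidance is that the closest measured thiourea, compound 3, sits at 80300 nM with a different five-membered aromatic ring in the same position. The expectation is that compound 4 stays in the same weak range as compound 3 rather than reaching a clearly better value.

For compound 4 the estimate in this assay is 70000 nM, with a range from 25000 nM to 200000 nM, and a real chance that only an inactive result is reported.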

Compound 4, half-maximal inhibitory concentration: 24400 nM
Compound 4: middle estimate off by 2.9-fold (0.46 log units), on the high side, and the stated range ends above it.
By their numbers in this assay, from the lowest: compound 4; then compounds 1 and 3 (each within the scatter of the next).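

The thiourea series now has a measured pair at this position: in this assay, 1,3-thiazol-2-yl in place of 3-methyl-1,2-oxazol-5-yl on the sulfonamide nitrogen gives a 3.3-fold lower number from compound 3 to compound 4 (0.52 log units; beyond the scatter), so the number responds modestly, but beyond the scatter, to the choice between these two five-membered aromatic rings. The change from compound 2 to compound 4 cannot be read as a step, as compound 2 is recorded only as "not active", whereas compound 4 gives 24400 nM with the 1,3-thiazol-2-yl group on the same nitrogen. No data at hand bear on the cause of the difference between compound 3 and compound 4.

Open, as far as these compounds go, is whether the step belongs to the ring itself or to the methyl group of compound 3, a question that an unsubstituted 1,2-oxazol-5-yl group on the sulfonamide nitrogen would address. Also open, from the compounds shown here alone, is whether a six-membered ring such as pyridin-2-yl, or a simple acetyl group, at this position would lower the number further than the 1,3-thiazol-2-yl group does.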